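The compounds below may be only part of what the source reports. "The series", "measured", "known", "first", "only" and "open" are said of these compounds alone.

In a functional assay on HEL cells (Homo sapiens) for cytotoxicity (on this read-out higher numbers stand for lower toxicity in this test and lower numbers for higher toxicity in this test), compound 2 (`CCCCCCC#Cc1cc2cn([C@@H]3O[C@H](CO)[C@@H](O)[C@H]3O)c(=O)nc2o1`) gives > 133000 nM, which is a limit and not a number. Compound 1 (`CCCCC#Cc1cc2cn(C)c(=O)nc2o1`) gives > 217000 nM, also a limit. Compound 3 (`CCCCC#Cc1cc2cn([C@H]3C[C@H](O)[C@@H](CO)O3)c(=O)nc2o1`) gives > 150000 nM, again a limit. None of the three therefore has an exact reading, and compound 2 cannot be ranked against the other two.

Compound 4 (`CCCCCCC#Cc1cc2cn([C@@H]3O[C@H](CO)[C@@H](O)[C@@H]3O)c(=O)nc2o1`) is a close relative of compound 2: the two compounds have the same atoms and bonds and differ only in configuration as drawn: 1 of 4 stereo elements differ; a stereocentre at a saturated ring carbon is drawn R in compound 2 and S in compound 4. A stereocentre at a saturated ring carbon is drawn R in compound 2 and S in compound 4, and nothing else changes.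

Only one measured step connects any of these compounds, a step that the two limits leave unreadable from compound 1 to compound 3. It involves a different structural change and gives no size to carry over. For the measured compounds named here, the only guide is that compound 1, compound 2 and compound 3 all reach limits, so compound 4 will probably report a limit too. The expected step that the limit leaves unreadable from compound 2 to compound 4 is no larger than the usual scatter, with no direction favoured.

Compound 4 is estimated at 140000 nM, within an expected range of 60000 nM to 280000 nM.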

Compound 4, half-maximal cytotoxic concentration: > 53000 nM
Compound 4 ended at the assay's limit; the forecaster's own chance of this, stated with the estimate: 75%; the middle value is on the limit's open side.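

In this assay compound 4 gives > 53000 nM, which is a limit and not a number. Compound 2 also reports only a limit, so no step can be read between compound 2 and compound 4. The compounds shown leave open whether the configuration at this one saturated ring carbon affects the read-out of this assay at all.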